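The compounds below may be only part of what the source reports. "The series", "measured", "known", "first", "only" and "open" are said of these compounds alone.

Measured in a functional assay on MCF7 cells (Homo sapiens) for antiproliferative activity, read by CCK-8 assay, with a stated time of 24 h; on this read-out lower numbers stand for stronger inhibition and higher numbers for weaker inhibition:
- Compound 1 `CCN(CC)Cc1ccc2nc(NC(=O)N/N=C(\C)c3ccccn3)sc2c1`: > 40000 nM (a limit, not a number)
- Compound 2 `CN(C)Cc1ccc(NC(=O)N/N=C/c2ccccn2)cc1`: > 40000 nM (a limit, not a number)

For the measured compounds named here, neither compound yields a number so far, and the whole picture is one reading: the limit of > 40000 nM in this assay, at which 2 of the 2 values shown sit. From the compounds shown here alone, compound 2 therefore stands at a limit, > 40000 nM, and its true value in this assay is unknown.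

Compound 3 `CC1CCN(Cc2ccc(NC(=O)N/N=C/c3ccccn3)cc2)CC1` keeps the core of compound 2 and changes one group: 4-methylpiperidin-1-yl in place of dimethylamino on a saturated chain carbon bound to an aromatic carbon. The new group is larger and brings a ring.

Going by the values given here, no pair of measured compounds shows what a single change does in this assay, so there is little to guide a forecast. The expectation rests mainly on compound 2, whose > 40000 nM is a limit. No shift beyond the usual scatter is expected, and another limit is the likeliest result. The estimated step of a number no higher from compound 2 to compound 3 (the limit leaves the size open) stays inside that scatter. For compound 3 the expected value is 40000 nM, with an estimated range from 15000 nM to 60000 nM.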

Compound 3, half-maximal inhibitory concentration: > 40000 nM
Compound 3: a limit, no number (the forecaster's own chance of this, stated with the estimate: 70%); the middle value lies on the limit itself.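

Compound 2 and compound 3 both end at a limit in this assay, so the step from dimethylamino to 4-methylpiperidin-1-yl cannot be read. The compounds shown leave open what the true values are and which change would bring a measurable number, and the whole picture remains a single reading: the limit of > 40000 nM in this assay, at which 3 of the 3 values shown sit.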